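Chloro-to-amino swap on a dichloropurine benzyl series

The source may report more compounds than this note shows. Statements on the series, on what has been measured and on what is new or still open speak of the compounds shown alone.

Measured so far, in a functional assay on ACHN cells (Homo sapiens) for cytotoxicity, read by sulforhodamine B assay, with a stated time of 48 h; on this read-out higher numbers stand for lower toxicity in this test and lower numbers for higher toxicity in this test:
compound 1 `ClCc1ccccc1Cn1cnc2c(Cl)nc(Cl)nc21`, 4160 nM
compound 2 `ClCc1cccc(Cn2cnc3c(Cl)nc(Cl)nc32)c1`, 7240 nM
compound 3 `Nc1nc(Cl)c2ncn(Cc3ccccc3CCl)c2n1`, 75900 nM

Compound 1 and compound 2 share the same atoms joined differently; the difference between the two cores is not broken down here, and their two numbers in this assay lie within the scatter of each other. Compound 3 is made from compound 1 by the change (amino in place of chloro on an aromatic carbon), and the step of an 18-fold higher number from compound 1 to compound 3 (1.26 log units; beyond the scatter) is the one large effect seen in the set.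

Compound 4 `Nc1nc(Cl)c2ncn(Cc3cccc(CCl)c3)c2n1` is not yet measured in this assay. Among the compounds with values here, it is made from compound 2 by the change (amino in place of chloro on an aromatic carbon), which is the same change as the one from compound 1 to compound 3: the groups that leave and enter and the place are the same word for word. This change occurs two times among the compounds shown, once measured. The expectation for compound 4 rests on a single measured instance, so its size is uncertain.

Because compound 3 gave 75900 nM after the same change, compound 4 is expected to show a step of a 15-fold higher number from compound 2 to compound 4 (1.18 log units; beyond the scatter), beside the measured step from compound 1 to compound 3. The estimate for compound 4 in this assay is 110000 nM, expected between 40000 nM and 300000 nM.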

Compound 4, concentration lethal to 50% of the cells: 29500 nM
Compound 4: middle estimate off by 3.7-fold (0.57 log units), on the high side, outside the stated range (below it).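

In this assay, amino in place of chloro on an aromatic carbon again gives a higher number, with a 4.1-fold higher number from compound 2 to compound 4 (0.61 log units; beyond the scatter), so the direction of the change holds on both cores, towards lower toxicity in this test. Within the data shown here, the size of the step does not carry over from one core to the other: the same change on two cores in this assay, an 18-fold higher number (1.26 log units; beyond the scatter) from compound 1 to compound 3 and a 4.1-fold higher number (0.61 log units; beyond the scatter) from compound 2 to compound 4, 4.5-fold (0.65 log units) apart, beyond the scatter of two such steps With only two cores, this shows neither a general rule for the direction nor a size that could be expected on a further core, and the figures do not show what sets the two steps apart.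

The compounds shown leave open whether a methylamino, dimethylamino or methoxy group on that same aromatic carbon, between two ring nitrogen atoms, would move the number as amino does. Among these compounds, they also leave open how much of the cytotoxicity depends on the chloromethyl group, since no compound here carries a methyl or hydroxymethyl group in its place.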